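Adding a chlorinated benzyl arm to a weak dioxygenase inhibitor

The source may report more compounds than this note shows. Statements on the series, on what has been measured and on what is new or still open speak of the compounds shown alone.

Of the compounds shown here, three sharing one core have been tested in an assay on isolated protein for inhibition of alpha-ketoglutarate-dependent dioxygenase alkB homolog 3 (Homo sapiens), read by polymerase chain reaction, with a stated time of 1 h; on this read-out higher numbers stand for weaker inhibition and lower numbers for stronger inhibition. Compound 1, `Cc1ccc2[nH]c(-n3[nH]c(C)c(C)c3=O)nc2c1`, gives 2600 nM. Compound 3, `COC(=O)Cc1c(C)[nH]n(-c2nc3ccccc3[nH]2)c1=O`, which carries a methyl ester chain on the same part of the core, gives 4300 nM; this value and that of compound 1 lie within the usual scatter, so the two cannot be told apart. Compound 2, `Cc1[nH]n(-c2nc3cc(C(F)(F)F)ccc3[nH]2)c(=O)c1Cc1ccccc1`, differs from compound 1 in two places, carrying a benzyl group where compound 1 has a methyl and a trifluoromethyl group on its core; compound 2 gives 610 nM, a clearly lower number than compound 1. Among the three, compound 1 therefore sits at the second highest number.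

The next compound, compound 4, `Cc1ccc2[nH]c(-n3[nH]c(C)c(Cc4ccccc4Cl)c3=O)nc2c1`, is not yet measured. It differs from compound 1 only by 2-chlorophenyl in place of hydrogen on a saturated chain carbon bound to an aromatic carbon. For the measured compounds named here, no single-change step between measured compounds covers this change. The expectation for compound 4 rests on compound 2, whose value of 610 nM is the only one here with a benzyl-type arm at that carbon. On that basis a step of a 3.7-fold lower number from compound 1 to compound 4 (0.57 log units; beyond the scatter) toward stronger inhibition is expected, beyond the scatter. Compound 4 is estimated at 700 nM, with a range from 250 nM to 2000 nM.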

Compound 4, half-maximal inhibitory concentration: 910 nM
Compound 4: the middle estimate sits 1.3-fold (0.11 log units) below what was measured, within the range that was stated.
By their numbers in this assay, from the lowest: compounds 2 and 4 (each within the scatter of the next); then compounds 1 and 3 (each within the scatter of the next).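

In this assay, replacing methyl with 2-chlorobenzyl on the core of compound 1 gives a 2.9-fold lower number from compound 1 to compound 4 (0.46 log units; beyond the scatter), a modest step that lies beyond the usual scatter. For the compounds shown here, this is the only comparison here in which the group at this carbon is the sole difference, whereas compound 2 carries a benzyl arm together with a trifluoromethyl group on its core, so its value could not show what the arm does alone. The result shows that this position accepts a much larger group, with an aromatic ring and a chlorine, and that inhibition gets stronger rather than being lost, although nothing available here explains why the number falls.

The compounds shown leave open how much of the step belongs to the chlorine and how much to the benzene ring that carries it. They also leave open how the number in this assay would respond to a longer chain, such as 2-phenylethyl, or to a carboxylic acid or an amine at this same carbon.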